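A few compounds are considered here, and "the series" means these few. Any claim that something is new, unique, unknown or untested is made for them only; others in the source may bear on it.

Measured so far in a functional assay on A549 cells (Homo sapiens) for antiproliferative activity, read by XTT assay, with a stated time of 72 h; on this read-out lower numbers stand for stronger inhibition and higher numbers for weaker inhibition:
compound 1 `COc1ccc(-c2cc3ccccc3nc2C=O)cc1`: > 10000 nM, a limit of the assay and not a number.
compound 2 `COc1ccc(-c2cc3ccccc3nc2/C=C/C(=O)c2ccc(OC)c(OC)c2)cc1`: 8860 nM.
compound 3 `COc1ccc(-c2cc3ccccc3nc2/C=C/C(=O)c2ccco2)cc1`: 6130 nM.

Compound 2 holds the highest of the two numbers; its nearest neighbour is compound 3, with a 1.4-fold lower number from compound 2 to compound 3 (0.16 log units; within the scatter). Compound 4 `COc1ccc(-c2cc3ccccc3nc2/C=C/C(=O)c2ccccn2)cc1` is not yet measured. It differs from compound 2 in one place: pyridin-2-yl in place of 3,4-dimethoxyphenyl on a carbonyl carbon. For the measured compounds named here, the one measured step at the same carbonyl carbon is a 1.4-fold lower number from compound 2 to compound 3 (0.16 log units; within the scatter), which stays within the scatter. The step of an at least 1.6-fold lower number from compound 1 to compound 3 (0.21 log units; that floor lies within the scatter) concerns another place and carries less weight. For compound 1 only a limit is known (the limit of > 10000 nM in this assay, at which 1 of the 3 values shown sits). The expected step is therefore a 1.2-fold lower number from compound 2 to compound 4 (0.07 log units; within the scatter), not beyond the scatter. Compound 4 is estimated at 7500 nM in this assay, within 3000 nM to 20000 nM.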

Compound 4, half-maximal inhibitory concentration: 6140 nM
Compound 4: the middle estimate sits 1.2-fold (0.09 log units) above what was measured, and the stated range covers the measured number.
By their numbers in this assay, from the lowest: compounds 3, 4 and 2 (each within the scatter of the next). At a limit, above all of these: compound 1.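

In this assay, three groups can now be compared on the carbonyl carbon, and pyridin-2-yl, the first of them with a ring nitrogen, stays within the scatter of both 3,4-dimethoxyphenyl (a 1.4-fold lower number from compound 2 to compound 4 (0.16 log units; within the scatter)) and furan-2-yl (a 1.0-fold higher number from compound 3 to compound 4 (0.00 log units; within the scatter)). Going from 10 heavy atoms to 6 at this place therefore leaves the number within the scatter. No measurement shown bears on why these steps are so small. On these data alone, whether an amine or a carboxylic acid on the ring at this carbonyl carbon would give a step beyond the scatter stays open.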